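Dichloropurine benzyl chlorides: amino for chloro on the core

The source may report more compounds than this note shows. Statements on the series, on what has been measured and on what is new or still open speak of the compounds shown alone.

Values in a functional assay on IGROV-1 cells (Homo sapiens) for cytotoxicity, read by sulforhodamine B assay, with a stated time of 48 h; a lower number here means a stronger inhibitor of growth, a higher number a weaker inhibitor of growth:
compound 1, `ClCc1ccccc1Cn1cnc2c(Cl)nc(Cl)nc21`: 3310 nM
compound 2, `ClCc1cccc(Cn2cnc3c(Cl)nc(Cl)nc32)c1`: 5120 nM
compound 3, `Nc1nc(Cl)c2ncn(Cc3ccccc3CCl)c2n1`: > 100000 nM, a limit of the assay rather than a number

Compound 1 and compound 2 have the same atoms joined differently; how their cores differ is not broken down here. In this assay compound 2 and compound 1 lie within the scatter of each other, so no order is read between them. One change has a measured outcome, amino in place of chloro on an aromatic carbon: an at least 30-fold higher number from compound 1 to compound 3 (1.48 log units; beyond the scatter). Compound 3 sits at the limit of > 100000 nM in this assay, at which 1 of the 3 values shown sits. Compound 4, `Nc1nc(Cl)c2ncn(Cc3cccc(CCl)c3)c2n1`, still unmeasured, arises from compound 2 by the same change, (amino in place of chloro on an aromatic carbon), at a place described in the same words. The step from compound 2 to compound 4 in this assay is expected to be a 29-fold higher number from compound 2 to compound 4 (1.47 log units; beyond the scatter), resting on an at least 30-fold higher number from compound 1 to compound 3 (1.48 log units; beyond the scatter). Compound 4 is estimated at 150000 nM, expected between 60000 nM and 400000 nM, most likely reported as a limit.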

Compound 4, concentration for total growth inhibition: 12900 nM
The estimate for compound 4 lay 12-fold (1.07 log units) above the measured number, outside the stated range (below it).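

In this assay the amino for chloro change gives a 2.5-fold higher number from compound 2 to compound 4 (0.40 log units; beyond the scatter), so a higher number is seen on both cores, but the size of the step does not carry over: the same change on two cores in this assay, an at least 30-fold higher number (1.48 log units; beyond the scatter) from compound 1 to compound 3 and a 2.5-fold higher number (0.40 log units; beyond the scatter) from compound 2 to compound 4, at least 11-fold (1.07 log units) apart, beyond the scatter of two such steps. The value of compound 3 is a limit of the assay, so the earlier step has a floor and no measured size: the limit of > 100000 nM in this assay, at which 1 of the 4 values shown sits. These two pairs show that the size of this step differs between these two cores, but they do not show what in the cores accounts for the gap or how the change would behave on any further core.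

Open, from the compounds shown here alone, is whether a methoxy or dimethylamino group on that aromatic carbon would behave as amino does on either core, and whether hydroxymethyl in place of chloromethyl would alter the step.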